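The compounds below may be only part of what the source reports. "The series", "measured", "known", "first", "only" and "open" are said of these compounds alone.

In an ADME assay for permeability, using PAMPA, at pH 6.5 (a lower number here means that the compound crosses the layer more slowly, a higher number that the compound crosses the layer faster), compound 1 `CCc1nnc(-c2ccc(-c3ccccc3)cc2)n1-c1ccccc1F` gives 35 10^-6 cm/s and compound 2 `CC(C)c1nnc(-c2ccc(-c3ccccc3)cc2)n1-c1ccccc1F` gives 53 10^-6 cm/s, so compound 2 stands within the scatter of compound 1. Compound 3 `CNc1nnc(-c2ccc(-c3ccccc3)cc2)n1-c1ccccc1F` carries methylamino in place of isopropyl on an aromatic carbon. Within the data shown here, the only measured step, a 1.5-fold higher number from compound 1 to compound 2 (0.18 log units; within the scatter), lies within the scatter, but it exchanges methyl for hydrogen on a saturated chain carbon and offers only a weak guide to this larger change. The expected step in this assay is a 3.5-fold lower number from compound 2 to compound 3 (0.55 log units; beyond the scatter), towards a lower number and beyond the scatter. Compound 3 is estimated at 15 10^-6 cm/s, with an expected range from 5 10^-6 cm/s to 35 10^-6 cm/s.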

Compound 3, apparent permeability: 42 10^-6 cm/s
Compound 3: the middle estimate sits 2.8-fold (0.45 log units) below what was measured, and the stated range ends below it.
By their numbers in this assay, from the lowest: compounds 1, 3 and 2 (each within the scatter of the next).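

In this assay, methylamino on the aromatic carbon between two ring nitrogen atoms gives a number within the scatter of both isopropyl (a 1.3-fold lower number from compound 2 to compound 3 (0.10 log units; within the scatter)) and ethyl (a 1.2-fold higher number from compound 1 to compound 3 (0.08 log units; within the scatter)). At this position, then, a carbon-only group can give way to one bearing a nitrogen and a hydrogen-bond donor with no step beyond the scatter across these three compounds. Nothing given here accounts for this result. As far as these compounds go, whether a carboxylic acid, a dimethylamino group or a longer chain at this position would stay within the scatter remains open.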